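Dimethoxyphenyl Replacing Dichlorophenyl on a Benzylamine Linker

This account rests on a few compounds, and the source may have more. Where it says the series, first, only, none or still open, it means among the compounds named here.

Of the compounds shown here, three sharing one core have been measured in a functional assay on EKVX cells (Homo sapiens) for inhibition, read by sulforhodamine B assay, with a stated time of 48 h; a lower number here means that less compound is tolerated, a higher number that more compound is tolerated. Compound 1, `Nc1cc(N)c2nc(-c3ccccc3)c(Oc3ccc(Cl)c(Cl)c3)nc2c1`, gives 41700 nM in this assay. Compound 2, `CCOC(=O)[C@H](CCC(=O)O)NC(=O)c1ccc(CNc2nc3cc(N)cc(N)c3nc2-c2ccccc2)cc1`, gives in this assay only a limit of the assay, < 100000 nM. Compound 3, `Nc1cc(N)c2nc(-c3ccccc3)c(NCc3ccc(Cl)c(Cl)c3)nc2c1`, likewise gives in this assay only a limit, < 100000 nM. Compound 3 therefore stands at the limit of < 100000 nM in this assay, at which 2 of the 3 values shown sit, without a number of its own, and compound 1 is the only one of the three with a numeric reading in this assay.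

Compound 4, `COc1ccc(CNc2nc3cc(N)cc(N)c3nc2-c2ccccc2)cc1OC`, has not been measured. The change from compound 3 to compound 4 is 3,4-dimethoxyphenyl in place of 3,4-dichlorophenyl on a saturated chain carbon bound to a nitrogen on an aromatic ring. No measured pair differs in exactly this way, so the effect of this swap is not shown by any step; the only guidance is that compound 3 and compound 2 both sit at the limit while compound 1 carries a number.

The step is expected to be a step that the limit leaves unreadable from compound 3 to compound 4, which is no step beyond the usual scatter. Compound 4 is estimated at 60000 nM in this assay, with a range from 20000 nM to 100000 nM, and with a fair chance that the assay again reports only a limit for compound 4.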

Compound 4, concentration lethal to 50% of the cells: < 100000 nM
Compound 4 gave a limit, no number; the forecaster's own chance of this, stated with the estimate: 50%; the middle value is on the limit's open side.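

Compound 3 and compound 4 both give only a limit in this assay, so no step can be read between them. Limits now make up most of the readings: the limit of < 100000 nM in this assay, at which 3 of the 4 values shown sit. The compounds shown leave open whether 3,4-dimethoxyphenyl in place of 3,4-dichlorophenyl changes the tolerated concentration at all.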